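A few compounds are considered here, and "the series" means these few. Any claim that something is new, unique, unknown or untested is made for them only; others in the source may bear on it.

The series shares one core, varied only on the amide-type nitrogen: compound 1 `CCN(CC)CCNC(=O)c1ccc(C(CC)(CC)c2ccc(OCS(=O)(=O)c3ccccc3)c(C)c2)n1CC` carries a 2-(diethylamino)ethyl, compound 2 `CCn1c(C(=O)NC2(CO)CC2)ccc1C(CC)(CC)c1ccc(OCS(=O)(=O)c2ccccc2)c(C)c1` a 1-(hydroxymethyl)cyclopropyl, compound 3 `CCn1c(C(=O)N[C@H](CO)CCCO)ccc1C(CC)(CC)c1ccc(OCS(=O)(=O)c2ccccc2)c(C)c1` a group of 7 heavy atoms (5 carbon, 2 oxygen; no ring). In a functional assay on BXPC-3 cells (Homo sapiens) for antiproliferative activity, read by MTT assay, with a stated time of 24 h (a higher number here means a weaker inhibitor, a lower number a stronger inhibitor), compound 1 gives 6270 nM and compound 2 gives 45400 nM. Compound 3 reaches only the limit of this assay, reported as > 50000 nM, so its standing is a floor rather than a number (the limit of > 50000 nM in this assay, at which 1 of the 3 values shown sits). The steps are a 7.2-fold higher number from compound 1 to compound 2 (0.86 log units; beyond the scatter), an at least 7.9-fold higher number from compound 1 to compound 3 (0.90 log units; beyond the scatter) and an at least 1.1-fold higher number from compound 2 to compound 3 (0.04 log units; that floor lies within the scatter). Compound 4 `CCn1c(C(=O)N[C@@H](CC(=O)O)C(=O)O)ccc1C(CC)(CC)c1ccc(OCS(=O)(=O)c2ccccc2)c(C)c1` carries the next change: a group of 8 heavy atoms (4 carbon, 4 oxygen; no ring) in place of a group of 7 heavy atoms (5 carbon, 2 oxygen; no ring), on an amide-type nitrogen. Both oxygen-bearing groups weakened compound 1 markedly, and compound 3 already stands at the limit, so no downward step beyond the scatter is expected. Compound 4 is estimated at 70000 nM, with a range of 25000 nM to 200000 nM, most probably again as a limit. The expected step is therefore a step that the limit leaves unreadable from compound 3 to compound 4.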

Compound 4, half-maximal inhibitory concentration: > 50000 nM
Compound 4: only a limit was reported; the forecaster's own chance of this, stated with the estimate: 80%; the middle value lies beyond the limit too.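

In this assay compound 4 gives > 50000 nM, which is a limit and not a number. The 1,2-dicarboxyethyl group thus also falls short of the 2-(diethylamino)ethyl group, with an at least 7.9-fold higher number from compound 1 to compound 4 (0.90 log units; beyond the scatter), while an at least 1.1-fold higher number from compound 2 to compound 4 (0.04 log units; that floor lies within the scatter) leaves compound 4 unseparated from compound 2. The step between compound 3 and compound 4 cannot be read, and the weak end of the series now rests largely on a ceiling: the limit of > 50000 nM in this assay, at which 2 of the 4 values shown sit.

As far as these compounds go, whether a longer chain ending in a dimethylamino group or a primary amine would match compound 1 stays open. From the compounds shown here alone, how far compound 3 and compound 4 lie past the limit also stays open.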